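A Methoxy Step Repeated on a Second Core

A few compounds are considered here, and "the series" means these few. Any claim that something is new, unique, unknown or untested is made for them only; others in the source may bear on it.

Compound 1 `COc1ccc(/C=C/C(=O)/C=C/c2ccc(OCc3cn(CCCCOc4cc(=O)oc5ccccc45)nn3)c(OC)c2)cc1OC` gives 59% in a functional assay on THP-1 cells (Homo sapiens) for inhibition, read by sulforhodamine B assay, with a stated time of 48 h, tested at 50 uM; a higher number here means more inhibition of growth at the concentration tested, a lower number less inhibition of growth. Compound 3 `COc1cc(/C=C/C(=O)/C=C/c2cc(OC)c(OC)c(OC)c2)ccc1OCc1cn(CCCCOc2cc(=O)oc3ccccc23)nn1` carries one change, (methoxy in place of hydrogen on an aromatic carbon), and in this assay compound 3 gives 65%, so the step of a number 6 percentage points higher from compound 1 to compound 3 (within the scatter) stays within the scatter. Compound 2 `COc1cccc(/C=C/C(=O)/C=C/c2ccc(OCc3cn(CCCOc4cc(=O)oc5ccccc45)nn3)c(OC)c2)c1` rests on a different core; how the two cores differ is not broken down here. In this assay compound 2 gives 58%, and its values and those of compound 1 and compound 3 lie within the scatter of one another.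

Compound 4 `COc1ccc(/C=C/C(=O)/C=C/c2ccc(OCc3cn(CCCOc4cc(=O)oc5ccccc45)nn3)c(OC)c2)cc1OC` has not yet been measured. It arises from compound 2 by methoxy in place of hydrogen on an aromatic carbon. Among the measured compounds shown here, this is the same kind of change as the one from compound 1 to compound 3, though its surroundings differ: here the methoxy enters para to a large group, whereas in compound 3 it entered meta to a large group and meta to a methoxy group. Because the earlier step of a number 6 percentage points higher from compound 1 to compound 3 (within the scatter) was small, the step from compound 2 to compound 4 in this assay is expected to be small as well, about a number 4 percentage points higher from compound 2 to compound 4 (within the scatter). Compound 4 is therefore estimated at 62%, within a range from 50% to 74%.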

Compound 4, percent growth inhibition at one concentration: 73%
The estimate for compound 4 lay 11 percentage points below the measured number, within the range that was stated.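

On the second core, methoxy in place of hydrogen on an aromatic carbon gives, in this assay, a number 15 percentage points higher from compound 2 to compound 4 (beyond the scatter), a step that stands clear of the scatter, whereas the same change on the first core does not. Even so, the two steps cannot be told apart: the same change on two cores in this assay, a number 6 percentage points higher (within the scatter) from compound 1 to compound 3 and a number 15 percentage points higher (beyond the scatter) from compound 2 to compound 4, 9 percentage points apart, within the scatter of two such steps. The result therefore gives no ground for saying that the change behaves differently on the two cores, but two pairs of compounds do not establish that it carries over by a fixed amount, or that it would raise the number on any further core in this series.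

The compounds shown leave open whether an amine or a carboxylic acid on that same aromatic carbon would follow the methoxy group. They also leave open whether the step seen here would hold at other concentrations, since each number is a single reading of growth inhibition at one concentration in one cell line.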